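Notes on a weak topoisomerase series, toward compound 4

A few compounds are considered here, and "the series" means these few. Any claim that something is new, unique, unknown or untested is made for them only; others in the source may bear on it.

Measured compounds:
compound 1 `CNC[C@@H]1CCN(c2cc3c(cc2F)c(=O)c(C(=O)O)cn3Cc2ccc(-n3cccn3)cc2)C1`, > 200000 nM
compound 2 `COc1c(N2CC[C@@H](CN)C2)c(F)cc2c(=O)c(C(=O)O)cn(Cc3ccc(-n4cccn4)cc3)c12`, > 200000 nM
compound 3 `COC(=O)c1cn(Cc2ccc(-c3ccccc3)cc2)c2c(OC)c(N3CC[C@@H](CN)C3)c(F)cc2c1=O`, 71400 nM

All three measured compounds were run in an assay on isolated protein for inhibition of DNA topoisomerase 1 (Homo sapiens), with a stated time of 15 min; a higher number here means a weaker inhibitor, a lower number a stronger inhibitor. For compound 1 the reading > 200000 nM is a limit of the assay and not a number. For compound 2 the reading > 200000 nM is likewise a limit. Among the compounds with values here, compound 3 gives 71400 nM in this assay, the only numerical reading among the three. Compound 1 therefore stands at the weak end of what is shown, on (the limit of > 200000 nM in this assay, at which 2 of the 3 values shown sit). Within the data shown here, no two measured compounds differ in a single place, so no measured step is available.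

Compound 4 `O=C(O)c1cn(Cc2ccc(-n3cccn3)cc2)c2cc(NC[C@@H]3CCNC3)c(F)cc2c1=O` has not yet been measured in this assay. It differs from compound 1 in one place: ((pyrrolidin-3-yl)methyl)amino in place of 3-((methylamino)methyl)pyrrolidin-1-yl on an aromatic carbon. Among the measured compounds shown here, with no measured step to anchor it and with compound 1 sitting only at a limit, the step from compound 1 to compound 4 is expected to be an at least 1.1-fold lower number from compound 1 to compound 4 (0.04 log units; that floor lies within the scatter), that is, nothing beyond the scatter, and a further limit reading is the most probable outcome. Compound 4 is accordingly estimated at 180000 nM in this assay, within a range of 60000 nM to 400000 nM.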

Compound 4, half-maximal inhibitory concentration: 200000 nM
Beside the measured number, compound 4's estimate is 1.1-fold (0.05 log units) below it, and the stated range covers the measured number.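

For compound 1 the reading > 200000 nM in this assay is a limit of the assay and not a number. With ((pyrrolidin-3-yl)methyl)amino in place of 3-((methylamino)methyl)pyrrolidin-1-yl on the aromatic carbon ortho to the fluoro group, the series gains its first single-place step, a number no higher from compound 1 to compound 4 (the limit leaves the size open), and the size of that step cannot be read. Compound 4 gives a plain number, yet that number stands at the same figure as the limit, so the change of attachment at this position brings no reading clearly clear of that end of the scale: the limit of > 200000 nM in this assay, at which 2 of the 4 values shown sit.

What the compounds shown leave open is whether any group on this aromatic carbon can move the reading well away from that figure, for instance a piperazin-1-yl ring or a longer aminoalkylamino chain. No pair shown isolates the carboxylic acid either, so a primary amide or the methyl ester on the core of compound 4 would be the direct single-place test of that group in this assay.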